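The compounds below may be only part of what the source reports. "The series", "measured", "known", "first", "only" and "open" are said of these compounds alone.

Working notes on the series. The compounds share one core and differ only in the aryl group on the saturated ring carbon between the two ring oxygen atoms. In a functional assay on the whole organism (Abdomen, strain albino) for inhibition, with Mus musculus as the target, in the writhing test, with stated times of 1 h and 8 min, at a dose of 10 mg/kg by the oral route (a lower number here means less inhibition, a higher number more inhibition at the dose given (going by the name of the read-out)), compound 2 `CC1=CC[C@@H]2[C@@H](O[C@H](c3ccc(Cl)cc3)OC2(C)C)[C@@H]1O` gives 88%, the highest of the three numbers measured. Compound 1 `CC1=CC[C@@H]2[C@@H](O[C@H](c3ccc(F)cc3)OC2(C)C)[C@@H]1O` gives 40%, and compound 3 `CC1=CC[C@@H]2[C@@H](O[C@H](c3ccc(Cl)c(Cl)c3)OC2(C)C)[C@@H]1O` gives 14%. The step of a number 48 percentage points higher from compound 1 to compound 2 (beyond the scatter) and the step of a number 74 percentage points lower from compound 2 to compound 3 (beyond the scatter) both lie beyond the scatter, so compound 2 stands clearly above the other two.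

Compound 4 `CC1=CC[C@@H]2[C@@H](O[C@H](c3cccc(F)c3)OC2(C)C)[C@@H]1O` is not yet measured. Its change from compound 2 is 3-fluorophenyl in place of 4-chlorophenyl on a saturated ring carbon. Among the measured compounds shown here, no measured step covers this change directly. The step of a number 48 percentage points higher from compound 1 to compound 2 (beyond the scatter) shows that fluoro on the aryl group went with a far lower number than chloro, and compound 1 carries the same halogen as compound 4; the step of a number 74 percentage points lower from compound 2 to compound 3 (beyond the scatter) shows that a change of the aryl group went with a much lower number. A large step down in this assay is therefore expected, a number 53 percentage points lower from compound 2 to compound 4 (beyond the scatter). Compound 4 is estimated at 35%, with a range from 10% to 65%.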

Compound 4, a percentage reported as inhibition, in the whole organism at one dose (the size of the read-out at that dose, not a potency): 40%
Beside the measured number, compound 4's estimate is 5 percentage points below it; low and high end bracket the measured number.
By their numbers in this assay, from the lowest: compound 3; then compounds 1 and 4 (each within the scatter of the next); then compound 2.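

In this assay, among the compounds shown here, 3-fluorophenyl in place of 4-fluorophenyl on the saturated ring carbon gives no change at the digits printed from compound 1 to compound 4 (within the scatter), so the two fluorophenyl groups cannot be told apart here, which the earlier compounds could not show. The step of a number 48 percentage points lower from compound 2 to compound 4 (beyond the scatter) shows that 3-fluorophenyl, like 4-fluorophenyl, stands clearly under 4-chlorophenyl, so among the monohalogenated compounds the high number goes with chloro alone, while compound 3, which also carries chloro, goes against any simple reading in favour of that halogen. Nothing available explains why 4-chlorophenyl stands apart from these groups.

As far as these compounds go, it stays open whether chloro keeps the number of compound 2 on any other carbon of the aryl group. From the compounds shown here alone, the outcome with a methoxy group or an amine in place of the halogen also stays open.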